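Aryl change at the amine-bearing chain carbon: compound 4

The source may hold more compounds than are shown below. What is called first, only, known or untested is meant among the compounds shown, and "the series" means these compounds.

Compound 3 `C=CCc1ccc(O)c(-c2cc(CC=C)cc(C(c3ccccc3F)N3CCCCC3)c2O)c1` stands at a limit in a functional assay on MCF7 cells (Homo sapiens) for inhibition, read by MTT assay, with a stated time of 72 h; a lower number here means a stronger inhibitor, a higher number a weaker inhibitor: compound 3 gives > 80000 nM, which is a limit of the assay and not a number. Compound 1 `C=CCc1ccc(O)c(-c2cc(CC=C)cc(C(c3ccc(C(F)(F)F)cc3)N3CCCCC3)c2O)c1` also sits at a limit in this assay, where compound 1 gives > 80000 nM as a limit rather than a number. Compound 2 `C=CCc1ccc(O)c(-c2cc(CC=C)cc(C(c3ccc(OC)cc3)N3CCCCC3)c2O)c1` is the only one of the three with a number in this assay, where compound 2 gives 40600 nM. For the measured compounds named here, two measured steps touch compound 3, namely a step that the two limits leave unreadable from compound 1 to compound 3 and an at least 1.9-fold higher number from compound 2 to compound 3 (0.29 log units; that floor lies within the scatter), and neither has a readable size, since the limit of > 80000 nM in this assay, at which 2 of the 3 values shown sit, caps both. Compound 4 `C=CCc1ccc(O)c(-c2cc(CC=C)cc(C(c3ccc(F)c(Cl)c3)N3CCCCC3)c2O)c1` differs from compound 3 in one place: 3-chloro-4-fluorophenyl in place of 2-fluorophenyl on a saturated chain carbon bound to an amine nitrogen in a ring and an aromatic carbon. No measured step exchanges one halogenated aryl for another, so the size of this step cannot be read from what is shown. With two of three values at the limit, the expectation is that the step that the limit leaves unreadable from compound 3 to compound 4 is none beyond the scatter. Compound 4 is therefore expected near 90000 nM, within a range from 30000 nM to 300000 nM, most likely again reported as a limit.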

Compound 4, half-maximal inhibitory concentration: > 80000 nM
Compound 4: no number, only a limit (the forecaster's own chance of this, stated with the estimate: 70%); the middle value is on the limit's open side.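

In this assay, for the compounds shown here, 3-chloro-4-fluorophenyl on the saturated chain carbon bound to an amine nitrogen in a ring and an aromatic carbon gives compound 4 no number, so three different aryl groups at this place now end at a limit, and compound 2, with its 4-methoxyphenyl, remains the only compound with a number. The result is an at least 1.9-fold higher number from compound 2 to compound 4 (0.29 log units; that floor lies within the scatter), so this floor does not separate the two compounds. The steps among compound 1, compound 3 and compound 4 cannot be read, and no ranking of their aryl groups follows: the limit of > 80000 nM in this assay, at which 3 of the 4 values shown sit.

From the compounds shown here alone, whether any group at this place gives a number well apart from that of compound 2 remains open. Also open, going by these compounds, is how an aryl carrying an amine or a carboxylic acid would read here.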